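The source may hold more compounds than are shown below. What is called first, only, known or untested is meant among the compounds shown, and "the series" means these compounds.

Three close relatives of one amide were tested in a functional assay on the whole organism (strain albino) for inhibition, with Rattus norvegicus as the target, read by paw edema, with stated times of 30 min and 1 h, at a dose of 0.28 mmol/kg by the oral route; a higher number here means more inhibition at the dose given (going by the name of the read-out), a lower number less inhibition. Compound 1, `CCn1c(SCC(=O)Nc2ccc(/C(C)=N/O)cc2)nnc1-c1ccc(OC)cc1`, carries an oxime on the outer ring; in this assay compound 1 gives 54%. Compound 2, `CCn1c(SCC(=O)Nc2ccc(C(C)=O)cc2)nnc1-c1ccc(OC)cc1`, keeps everything else but bears an acetyl instead, and compound 2 gives 51%. The difference between them is a group of 3 heavy atoms (2 carbon, 1 oxygen; no ring) in place of a group of 4 heavy atoms (2 carbon, 1 nitrogen, 1 oxygen; no ring), on an aromatic carbon, and it made a number 3 percentage points lower from compound 1 to compound 2 (within the scatter). Compound 3, `C=CCn1c(SCC(=O)Nc2ccc(/C(C)=N/O)cc2)nnc1-c1ccc(OC)cc1`, returns to the oxime but changes the chain on the ring nitrogen; compound 3 gives 54%. The two cores differ by vinyl in place of methyl on a saturated chain carbon bound to an aromatic nitrogen, a change that made no change at the digits printed from compound 1 to compound 3 (within the scatter), so compounds 1 and 3 stand level at the digits given, and compound 2 is within the scatter of both.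

Compound 4, `C=CCn1c(SCC(=O)Nc2ccc(C(C)=O)cc2)nnc1-c1ccc(OC)cc1`, has not been measured. For the measured compounds named here, it differs from compound 3 by a group of 3 heavy atoms (2 carbon, 1 oxygen; no ring) in place of a group of 4 heavy atoms (2 carbon, 1 nitrogen, 1 oxygen; no ring), on an aromatic carbon, and since the place of the change reads the same in both pairs, this is the same change as the one from compound 1 to compound 2. In the earlier pair that change stayed inside the scatter. The expected step is therefore a number 3 percentage points lower from compound 3 to compound 4 (within the scatter), resting on compound 1 and compound 2, where the same change gave a number 3 percentage points lower from compound 1 to compound 2 (within the scatter). Compound 4 is accordingly expected to give about 51%. The estimate for compound 4 is expected to lie between 40% and 62%.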

Compound 4, a percentage reported as inhibition, in the whole organism at one dose (the size of the read-out at that dose, not a potency): 50%
Estimate against measurement, compound 4: 1 percentage points above; the measured number falls inside the stated range.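

In this assay, replacing the oxime with acetyl on the second core gave a number 4 percentage points lower from compound 3 to compound 4 (within the scatter), and this can be set beside the same replacement on the first core: the same change on two cores in this assay, a number 3 percentage points lower (within the scatter) from compound 1 to compound 2 and a number 4 percentage points lower (within the scatter) from compound 3 to compound 4, 1 percentage points apart, within the scatter of two such steps The other change, vinyl in place of methyl on the chain at the ring nitrogen, gave a number 1 percentage points lower from compound 2 to compound 4 (within the scatter), and it too reads alike on both cores: the same change on two cores in this assay, no change at the digits printed (within the scatter) from compound 1 to compound 3 and a number 1 percentage points lower (within the scatter) from compound 2 to compound 4, 1 percentage points apart, within the scatter of two such steps Together these pairs show that neither change moved the number beyond the usual scatter on either core, but they do not show that either change has a real effect of a shared size or direction, and with every step this small, they are a weak test of whether an effect carries from one core to another.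

The compounds shown leave open whether a more different group on the aromatic carbon, such as an amine or a carboxylic acid in place of the acetyl, or a longer chain such as butyl on the ring nitrogen, would move the number beyond the scatter. A single dose also leaves open whether these compounds would still read alike at other doses, since the read-out gives the size of the inhibition at that dose and not a potency.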